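Swapping Phenyl for Benzofuran: Expected Cytotoxicity of Compound 4

The compounds below may be only part of what the source reports. "The series", "measured", "known", "first", "only" and "open" are said of these compounds alone.

Compound 1, `c1ccc(-c2ccc(Cn3cncc3CNc3ccc(-c4ccccc4)c(-c4ccccc4)c3)cc2)cc1`: in a toxicity assay on NIH3T3 cells (Mus musculus) for cytotoxicity, read by resazurin assay (on this read-out lower numbers stand for an effect already at smaller amounts and higher numbers for an effect only at larger amounts of compound), compound 1 gives > 10000 nM, which is a limit of the assay rather than a number.
Compound 2, `COC(=O)c1ccc(NCc2cncn2Cc2ccccc2N)cc1-c1ccccc1`: in this assay compound 2 gives 25000 nM.
Compound 3, `c1ccc(-c2ccc(Cn3cncc3CNc3ccc(-c4ccccc4)cc3)cc2)cc1`: in this assay compound 3 gives > 10000 nM, again a limit and not a number.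

Compound 1 thus stands at the edge of what this assay can report: its value is only a limit, and the same holds for compound 3, so two of the three values shown sit at that limit (the limit of > 10000 nM in this assay, at which 2 of the 3 values shown sit). Only compound 2 has a numerical value, and it is a weak one. For the measured compounds named here, the single step between measured compounds that differ in one place, a step that the two limits leave unreadable from compound 1 to compound 3, cannot be sized, since both ends are limits.

Compound 4, `c1ccc(-c2ccc(Cn3cncc3CNc3ccc(-c4cc5ccccc5o4)c(-c4ccccc4)c3)cc2)cc1`, differs from compound 1 in one place: 1-benzofuran-2-yl in place of phenyl on an aromatic carbon. Going by the values given here, no measured step involves a 1-benzofuran-2-yl group, and the only measured step is unreadable, so nothing suggests a move beyond the scatter in this assay. Compound 4 is therefore expected to remain at or near the limit, with an estimate of 20000 nM, between 8000 nM and 60000 nM. The expected step that the limit leaves unreadable from compound 1 to compound 4 is, in effect, none that the assay would resolve.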

Compound 4, half-maximal effective concentration: > 10000 nM
Compound 4 was reported as a limit; the forecaster's own chance of this, stated with the estimate: 70%; the middle value lies beyond the limit too.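

In this assay, for the compounds shown here, compound 1 and compound 4 are both reported only as limits, not as numbers, so the swap of phenyl for 1-benzofuran-2-yl yields no step that can be read. Most values now sit there: the limit of > 10000 nM in this assay, at which 3 of the 4 values shown sit. The compounds shown leave open at what concentration compound 1, compound 3 and compound 4 would show an effect on these cells, and whether this swap changes it at all.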